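The source may report more compounds than this note shows. Statements on the series, on what has been measured and on what is new or still open speak of the compounds shown alone.

Measured so far in a functional assay on HEK293 cells for agonist activity at probable G-protein coupled receptor 27 (Homo sapiens), read by a luciferase reporter and beta-arrestin recruitment, with a stated time of 10 min; a lower number here means that less compound is needed, a higher number that more compound is needed for the effect:
compound 1 `O=C(Nc1cccc(S(=O)(=O)Nc2ccccc2)c1)c1ccc(Cl)cc1Cl`: > 100000 nM, a limit of the assay, not a number
compound 2 `O=C(Nc1ccc(S(=O)(=O)Nc2ccc(Cl)cc2)cc1)c1ccc(Cl)cc1Cl`: > 100000 nM, a limit of the assay, not a number
compound 3 `O=C(Nc1ccc(S(=O)(=O)Nc2ccccc2)cc1)c1ccc(Cl)cc1F`: 3980 nM

Compound 2 stands at the limit of > 100000 nM in this assay, at which 2 of the 3 values shown sit, so for it only a limit is known and no number. Within the data shown here, compound 3 is the only member of the series with a measured number in this assay; it differs from compound 2 in two places, and no single-point step between measured compounds exists, so nothing of the size of such steps has been observed.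

Compound 4 `Cc1ccccc1NS(=O)(=O)c1ccc(NC(=O)c2ccc(Cl)cc2Cl)cc1` is not yet measured. It differs from compound 2 by 2-methylphenyl in place of 4-chlorophenyl on a sulfonamide nitrogen. Among the measured compounds shown here, with no measured step to lean on, the expectation rests on the change itself and on the fact that two of three values sit at the limit. The expected step is an at least 2.5-fold lower number from compound 2 to compound 4 (0.39 log units; beyond the scatter), that is, a gain that may reach beyond the scatter but most likely leaves compound 4 weak, and the result may again be reported only as a limit. Compound 4 is estimated at 40000 nM, with a range from 4000 nM to 200000 nM.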

Compound 4, half-maximal effective concentration: 1230 nM
Estimate against measurement, compound 4: 33-fold (1.51 log units) above, outside the stated range (below it).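

In this assay, among these compounds, 2-methylphenyl in place of 4-chlorophenyl on a sulfonamide nitrogen gives an at least 81-fold lower number from compound 2 to compound 4 (1.91 log units; beyond the scatter), the first single-place step and a large one. From the compounds shown here alone, compound 2 is known only as a limit, so this step has a lower bound and its true size remains unknown: the limit of > 100000 nM in this assay, at which 2 of the 4 values shown sit. The substituted phenyl on the sulfonamide nitrogen is therefore a place where one change can carry a compound from the limit to a measured number, even though the leaving and entering groups have the same heavy-atom count, the same aromatic ring of carbon only, and no hydrogen-bond donors or acceptors.

The change replaces chlorine with a methyl group and also moves the substituent from the 4 to the 2 position in the group names, so the compounds shown do not separate these two differences. 2-Chlorophenyl and 4-methylphenyl on the same nitrogen would separate them, while 2-methoxyphenyl would show whether the gain extends beyond the methyl group.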